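The compounds below may be only part of what the source reports. "The series", "measured", "known", "first", "only" and "open" are said of these compounds alone.

In a functional assay on BT-474 cells (Homo sapiens) for inhibition, read by MTT assay, with a stated time of 5 days (a lower number here means a stronger inhibitor, a higher number a weaker inhibitor), compound 1 `Cc1cc(Nc2nc(NCc3ccccc3F)nc3[nH]ncc23)n[nH]1` gives 13200 nM and compound 2 `Cc1cc(Nc2nc(NCc3ccccc3Cl)nc3[nH]ncc23)n[nH]1` gives 7160 nM, two numbers within the scatter of each other. Compound 3 `Cc1cc(Nc2nc(NCc3ccccc3Br)nc3[nH]ncc23)n[nH]1` differs from compound 2 by bromo in place of chloro on an aromatic carbon. Going by the values given here, the only measured step that bears on this, chloro in place of fluoro on an aromatic carbon, is a 1.8-fold lower number from compound 1 to compound 2 (0.27 log units; within the scatter) and stays within the scatter, so no step beyond the scatter is expected in this assay. For compound 3 the estimated value is 6000 nM, with an expected range from 2500 nM to 13000 nM. The estimate means a 1.2-fold lower number from compound 2 to compound 3 (0.08 log units; within the scatter), which is expected to stay within the scatter.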

Compound 3, half-maximal inhibitory concentration: 10100 nM
The estimate for compound 3 lay 1.7-fold (0.23 log units) below the measured number; the measured number falls inside the stated range.
By their numbers in this assay, from the lowest: compounds 2, 3 and 1 (each within the scatter of the next).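

In this assay, bromo at this place gives a 1.4-fold higher number from compound 2 to compound 3 (0.15 log units; within the scatter) and a 1.3-fold lower number from compound 1 to compound 3 (0.12 log units; within the scatter) and so neither new step leaves the scatter. With fluoro, chloro and bromo now all read on this aromatic carbon of the 2-halobenzyl group, compounds 1, 2 and 3 show no separation, and exchanging one of these halogens for another does not shift the number beyond the scatter. No measurement given here offers an explanation for this. Still open, on these data alone, is whether a group that is not a halogen at this place, such as methoxy or an amine, would move the number beyond the scatter. Also open, as far as these compounds go, is whether a halogen on another carbon of this ring would do so.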